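A few compounds are considered here, and "the series" means these few. Any claim that something is new, unique, unknown or untested is made for them only; others in the source may bear on it.

Within the data shown here, in a functional assay on A549 cells (Homo sapiens) for antiproliferative activity, read by MTT assay, with a stated time of 72 h (on this read-out lower numbers stand for stronger inhibition and higher numbers for weaker inhibition), compound 1 `COc1ccc(/C=C/C(=O)/C=C/c2nc(C)c(C)nc2C)cc1` gives 3500 nM and compound 2 `COc1ccc(/C=C/C(=O)/C=C/c2nc(C)c(C)nc2C)cc1OC` gives 3790 nM as its only measured neighbour, so the two stand level. Compound 3 `Cc1nc(C)c(/C=C/C(=O)/C=C/c2ccc([N+](=O)[O-])cc2)nc1C` is still unmeasured. Its change from compound 1 is nitro in place of methoxy on an aromatic carbon with nitro in place of methoxy on an aromatic carbon, para to a large group. Among the measured compounds shown here, the only measured step that bears on this is a 1.1-fold higher number from compound 1 to compound 2 (0.03 log units; within the scatter) with methoxy in place of hydrogen on an aromatic carbon. For the measured compounds named here, that step lies within the scatter and is only weak guidance, since it removes no methoxy and no measured compound here carries a nitro. No step beyond the scatter is therefore expected in this assay in either direction, though the range must stay wide. The expected change is a 1.1-fold lower number from compound 1 to compound 3 (0.04 log units; within the scatter) and so stays small. The estimate for compound 3 is 3200 nM with 1100 nM to 9000 nM as its expected range.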

Compound 3, half-maximal inhibitory concentration: 9600 nM
Beside the measured number, compound 3's estimate is 3.0-fold (0.48 log units) below it; measured number outside the range, above it.
By their numbers in this assay, from the lowest: compounds 1 and 2 (each within the scatter of the next); then compound 3.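

In this assay, the aromatic carbon para to a large group proves sensitive to what sits on it: nitro in place of methoxy gives a 2.7-fold higher number from compound 1 to compound 3 (0.44 log units; beyond the scatter), a modest step towards weaker inhibition. Compound 1 and compound 2, which differ by one added methoxy, stand level, so this is the first change among the compounds shown that moves the number beyond the scatter. No measurement at hand accounts for this step, so its cause stays unknown.

The compounds shown cannot separate the loss of methoxy from the arrival of nitro, since both happen in the same step. On these data alone, it also remains open how a plain hydrogen, an amine or a chlorine atom at this place would compare with methoxy and nitro.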